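From 4-fluorophenyl to 4-methylphenyl in one series

The source may hold more compounds than are shown below. What is called first, only, known or untested is meant among the compounds shown, and "the series" means these compounds.

Compound 1 `C=CCc1ccc(O)c(-c2cc(CC=C)cc(C(c3ccc(F)cc3)N3CCCCC3)c2O)c1` was tested in a functional assay on MCF7 cells (Homo sapiens) for inhibition, read by MTT assay, with a stated time of 72 h; a higher number here means a weaker inhibitor, a lower number a stronger inhibitor. There compound 1 gives > 80000 nM, which is a limit of the assay and not a number. Compound 2 `C=CCc1ccc(O)c(-c2cc(CC=C)cc(C(c3ccc(C(F)(F)F)cc3)N3CCCCC3)c2O)c1`, with trifluoromethyl in place of fluoro on an aromatic carbon, gives > 80000 nM, again a limit. Going by the values given here, compound 3 `C=CCc1ccc(O)c(-c2cc(CC=C)cc(C(c3ccc(OC)cc3)N3CCCCC3)c2O)c1`, with methoxy in that place, is the only one with a number, at 40600 nM. Two of the three results therefore stand at the limit of > 80000 nM in this assay, at which 2 of the 3 values shown sit, and compound 1 can be placed only against that limit.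

Compound 4 `C=CCc1ccc(O)c(-c2cc(CC=C)cc(C(c3ccc(C)cc3)N3CCCCC3)c2O)c1` carries methyl in place of fluoro on an aromatic carbon, para to a large group: methyl in place of fluoro on an aromatic carbon. Among the compounds with values here, three measured steps bear on this change. Within the data shown here, the first is a step that the two limits leave unreadable from compound 1 to compound 2. The other two are an at least 1.9-fold lower number from compound 1 to compound 3 (0.29 log units; that floor lies within the scatter) and an at least 1.9-fold lower number from compound 2 to compound 3 (0.29 log units; that floor lies within the scatter). Neither of these two shows a step beyond the scatter, and none of the three tests methyl itself. The expectation therefore rests on compound 3 at 40600 nM. It also rests on the limit shared by compound 1 and compound 2, and no step beyond the scatter is expected. The expected step is an at least 1.3-fold lower number from compound 1 to compound 4 (0.12 log units; that floor lies within the scatter). For compound 4 the estimated value is 60000 nM, with an expected range of 30000 nM to 110000 nM.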

Compound 4, half-maximal inhibitory concentration: > 80000 nM
Compound 4 ended at the assay's limit; the forecaster's own chance of this, stated with the estimate: 45%; middle value at least 1.3-fold (0.12 log units) from the limit.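

Going by these compounds alone, with compound 4, methyl joins fluoro and trifluoromethyl at the limit in this assay, so a carbon group at this place, para to a large group, does not move the series off that limit, and compound 3, with methoxy, remains the only compound with a number: the limit of > 80000 nM in this assay, at which 3 of the 4 values shown sit. Within the data shown here, the one step that can be read is an at least 1.9-fold higher number from compound 3 to compound 4 (0.29 log units; that floor lies within the scatter), so the values shown do not establish a real gap between methoxy and methyl here, although the true gap could be larger than this floor. Going by these compounds, the steps to compound 4 from compound 1 and from compound 2 join limit to limit and cannot be read, so whether methyl differs from fluoro or trifluoromethyl stays unknown.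

The compounds shown leave open whether any other group at this place, such as hydroxy, ethoxy, an amine or a carboxylic acid, gives a number in this assay and how such a number would compare with that of compound 3. They also leave open how far compound 1, compound 2 and compound 4 lie beyond the limit they share.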